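Removing a Methyl From the Fused Core

The source may report more compounds than this note shows. Statements on the series, on what has been measured and on what is new or still open speak of the compounds shown alone.

The study concerns four compounds that share a fused core bearing a methoxyphenyl group. Compound 1 `COc1ccc(-c2cc(O)c3c(C)cc(C)nc3n2)cc1` heads one pair; in a functional assay on HCT-116 cells (Homo sapiens) (a lower number here means a stronger inhibitor of growth, a higher number a weaker inhibitor of growth), compound 1 gives 36300 nM. Compound 3 `COc1ccc(-c2cc(O)c3ccc(C)nc3n2)cc1` differs from it in one place: hydrogen in place of methyl on an aromatic carbon. The step of an at least 2.7-fold higher number from compound 1 to compound 3 (0.44 log units; beyond the scatter) is known only as a bound, because compound 3 reaches (the limit of > 100000 nM in this assay, at which 1 of the 3 values shown sits). For compound 3 the assay therefore reports only a limit, > 100000 nM.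

Compound 2 `COc1cccc(-c2cc(O)c3c(C)ccnc3n2)c1` has a different core; the difference between the two cores is not broken down here. In this assay compound 2 gives 44.7 nM, the lowest number reported among the measured compounds.

Compound 4 `COc1cccc(-c2cc(O)c3cccnc3n2)c1` is not yet measured. It arises from compound 2 through (hydrogen in place of methyl on an aromatic carbon), the same kind of change as before, though the earlier place was also meta to a methyl group. Because the earlier pair shows an at least 2.7-fold higher number from compound 1 to compound 3 (0.44 log units; beyond the scatter), compound 4 is expected to give a higher number than compound 2, a step of about a 4.0-fold higher number from compound 2 to compound 4 (0.60 log units; beyond the scatter). Compound 4 is therefore estimated at 180 nM, most likely between 45 nM and 700 nM.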

Compound 4, concentration for 50% growth inhibition: 36.3 nM
Compound 4: middle estimate off by 5.0-fold (0.70 log units), on the high side, and the stated range ends above it.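

On the second core, in this assay, hydrogen in place of methyl on an aromatic carbon gives a 1.2-fold lower number from compound 2 to compound 4 (0.09 log units; within the scatter), so here the methyl can be lost with no change beyond the scatter. Set beside the first pair, the same change does not carry over from one core to the other as a fixed step: the same change on two cores in this assay, an at least 2.7-fold higher number (0.44 log units; beyond the scatter) from compound 1 to compound 3 and a 1.2-fold lower number (0.09 log units; within the scatter) from compound 2 to compound 4, at least 3.3-fold (0.53 log units) apart, beyond the scatter of two such steps With only one pair on each core, this does not show which feature of the cores separates the two results, and the first step remains a bound rather than a measured size.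

The compounds shown leave open whether the placing of the methoxy group or the further methyl on the core of compound 1 decides how the change behaves. They also leave open how an ethyl group, a chlorine or an amine at that same carbon would compare with the hydrogen of compound 4, which gives 36.3 nM.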